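Benzofuranyl pyrazoline amides: Vero cytotoxicity, styryl replacement

A few compounds are considered here, and "the series" means these few. Any claim that something is new, unique, unknown or untested is made for them only; others in the source may bear on it.

Cytotoxicity on host cells is followed in an ADME assay on Vero cells (Chlorocebus sabaeus) for cytotoxicity, read by MTT assay, with a stated time of 72 h; on this read-out higher numbers stand for weaker inhibition and lower numbers for stronger inhibition. Two members of the series carry values there, both of them limits of the assay rather than numbers. Compound 1 `O=C(c1ccncc1)N1N=C(c2cc3ccccc3o2)CC1c1ccccc1` gives in this assay > 209000 nM, a limit. Compound 2 `CCn1cc(C(=O)N2N=C(c3cc4ccccc4o3)CC2c2ccc(Cl)cc2)c(=O)c2ccc(C)nc21` gives in this assay > 160000 nM, likewise a limit. Among the compounds with values here, compound 2 therefore stands at one of the two limits recorded, (the limit of > 160000 nM in this assay, at which 1 of the 2 values shown sits), and compound 1 stands at the other, (the limit of > 209000 nM in this assay, at which 1 of the 2 values shown sits); neither value separates the two, and no step between them can be stated.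

Compound 3 `CCn1cc(C(=O)N2N=C(c3cc4ccccc4o3)CC2/C=C/c2ccccc2)c(=O)c2ccc(C)nc21` differs from compound 2 in one place: 2-phenylethenyl in place of 4-chlorophenyl on a saturated ring carbon, in words 2-phenylethenyl in place of 4-chlorophenyl on a saturated ring carbon. Within the data shown here, no measured step covers this change. With both recorded values sitting at limits, the expected step from compound 2 to compound 3, a step that the limit leaves unreadable from compound 2 to compound 3, is none beyond the scatter, and the expectation is that compound 3 again shows no measurable cytotoxicity. Compound 3 is estimated in this assay at 180000 nM, within 70000 nM to 500000 nM, most likely reported as a limit.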

Compound 3, half-maximal inhibitory concentration: > 168000 nM
Compound 3: only a limit was reported (the forecaster's own chance of this, stated with the estimate: 75%); the middle value lies beyond the limit too.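

In this assay compound 3 gives > 168000 nM as a limit. Compound 2 also stands at a limit, so the step to compound 3, 2-phenylethenyl in place of 4-chlorophenyl on a saturated ring carbon, cannot be read. The compounds shown leave open whether any of them reaches a measurable half-maximal concentration in this assay and whether this replacement alters it.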